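The source may report more compounds than this note shows. Statements on the series, on what has been measured and on what is new or still open speak of the compounds shown alone.

Measured so far in a functional assay on HL-60 cells (Homo sapiens) for cytotoxicity, read by luminescence and CellTiter-Glo, with a stated time of 3 days; a lower number here means a stronger inhibitor, a higher number a weaker inhibitor:
- compound 1 `O=C(Nc1cc(C(F)(F)F)cc(C(F)(F)F)c1)c1cc(Br)ccc1O` gives 290 nM
- compound 2 `O=C(Nc1cc(C(F)(F)F)cc(C(F)(F)F)c1)c1ccc(Cl)cc1O` gives 200 nM
- compound 3 `N#Cc1ccc(NC(=O)c2ccc3cccnc3c2O)c(Cl)c1` gives 910 nM

For the measured compounds named here, compound 2 stands at the lowest number of the three, but the only one-place step to it, a 1.5-fold lower number from compound 1 to compound 2 (0.16 log units; within the scatter), lies within the scatter, so compounds 1 and 2 cannot be ordered; only the gap to compound 3 is beyond the scatter.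

Compound 4 `O=C(Nc1cc(C(F)(F)F)cc(C(F)(F)F)c1)c1ccc(-c2ccccc2)cc1O` differs from compound 2 by phenyl in place of chloro on an aromatic carbon. Going by the values given here, no measured step bears directly on a halogen giving way to an aromatic ring; the single step known, a 1.5-fold lower number from compound 1 to compound 2 (0.16 log units; within the scatter), concerns a halogen change only. The expected step is therefore a 1.1-fold higher number from compound 2 to compound 4 (0.04 log units; within the scatter), with no direction claimed beyond the scatter. Compound 4 is estimated at 220 nM, in the range 60 nM to 800 nM.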

Compound 4, half-maximal inhibitory concentration: 1140 nM
Estimate against measurement, compound 4: 5.2-fold (0.71 log units) below, outside the stated range (above it).
By their numbers in this assay, from the lowest: compounds 2 and 1 (each within the scatter of the next); then compounds 3 and 4 (each within the scatter of the next).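

In this assay, phenyl in place of chloro on this aromatic carbon, meta to a hydroxy group and para to a large group, gives a 5.7-fold higher number from compound 2 to compound 4 (0.76 log units; beyond the scatter). At this position, the number therefore responds to a change from a halogen to a six-membered aromatic ring, and this single pair marks phenyl as the less favourable of the two groups. Nothing measured on these compounds accounts for the rise.

From the compounds shown here alone, whether a methyl or an amine here would stay close to compound 2 remains open. So does whether a carboxylic acid on the added phenyl would alter the step.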